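Swapping a Thiazole for a Furan on the Cyclopropane

The source may report more compounds than this note shows. Statements on the series, on what has been measured and on what is new or still open speak of the compounds shown alone.

For the measured compounds named here, compound 2 `CC[C@H](C)[C@H](N)CN(C(=O)[C@@H]1C[C@H]1c1nccs1)c1ccc(-c2ccccc2)cc1` stands at the lower of the two numbers measured so far in a functional assay for agonist activity at G protein-coupled receptor 88 (Homo sapiens), read by HTRF and cAMP accumulation (on this read-out lower numbers stand for an effect already at smaller amounts and higher numbers for an effect only at larger amounts of compound), giving 210 nM. Going by the values given here, compound 1 `CC[C@H](C)[C@H](N)CN(C(=O)[C@@H]1C[C@H]1c1cccc(OC)c1)c1ccc(-c2ccccc2)cc1` gives 3000 nM, and the single measured step is a 14-fold lower number from compound 1 to compound 2 (1.15 log units; beyond the scatter). Compound 3 `CC[C@H](C)[C@H](N)CN(C(=O)[C@@H]1C[C@H]1c1ccoc1)c1ccc(-c2ccccc2)cc1` differs from compound 2 by furan-3-yl in place of 1,3-thiazol-2-yl on a saturated ring carbon. Among the compounds with values here, only that one step bears on the new change, and it concerned a different replacement on the same carbon, so it offers no firm direction. A moderate loss is expected, with compound 3 estimated at 600 nM, in a range from 150 nM to 2500 nM. The expected step is a 2.9-fold higher number from compound 2 to compound 3 (0.46 log units; beyond the scatter).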

Compound 3, half-maximal effective concentration: 580 nM
Compound 3: middle estimate off by 1.0-fold (0.01 log units), on the high side; the range from low to high includes it.
By their numbers in this assay, from the lowest: compound 2; then compound 3; then compound 1.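

Furan-3-yl on this saturated ring carbon keeps part of the gain over 3-methoxyphenyl, giving a 5.2-fold lower number from compound 1 to compound 3 (0.71 log units; beyond the scatter) and yet falling short of 1,3-thiazol-2-yl with a 2.8-fold higher number from compound 2 to compound 3 (0.44 log units; beyond the scatter) in the other comparison. Two five-membered aromatic rings with the same heavy-atom count are therefore told apart at this carbon. Nothing available explains why these two rings differ. As far as these compounds go, whether a methyl group or an amine on the 1,3-thiazol-2-yl ring would lower the number further stays open. From the compounds shown here alone, how a pyridine ring would compare at this carbon also stays open.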